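The source may report more compounds than this note shows. Statements on the series, on what has been measured and on what is new or still open speak of the compounds shown alone.

Compound 1: `C=CCn1c(=O)/c(=C\c2ccc(Cl)c(Cl)c2)[nH]c(=O)/c1=C\c1ccccc1OC` gives "not active" (no number reported) in a functional assay on MOLT-4 cells (Homo sapiens) for cytotoxicity, read by CCK-8 assay, with a stated time of 72 h; a higher number here means a weaker inhibitor, a lower number a stronger inhibitor.
Compound 2: `C=CCn1c(=O)/c(=C\c2cccc(Br)c2)[nH]c(=O)/c1=C\c1ccccc1OC` gives 5000 nM in this assay.
Compound 3: `C=CCn1c(=O)/c(=C\c2cccc(Br)c2)[nH]c(=O)/c1=C\c1cccc(Br)c1` gives "not active" (no number reported) in this assay.

Among the measured compounds shown here, of the three measured compounds, compound 2 is the only one for which a number is reported; compound 1 and compound 3 are each recorded as not active, without a figure. Compound 2 therefore stands alone on the numbers shown, and no step between two measured compounds can be drawn from this set.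

Compound 4, `C=CCn1c(=O)/c(=C\c2ccccc2F)[nH]c(=O)/c1=C\c1ccccc1OC`, is not yet measured. It differs from compound 2 in one place: 2-fluorophenyl in place of 3-bromophenyl on a double-bonded chain carbon bound to an aromatic carbon. For the measured compounds named here, because the only number in hand is compound 2 at 5000 nM, there is no step among measured compounds from which to read the size of such an exchange; compound 1 and compound 3 show only that other choices of the aryl groups on this shared core lose activity altogether. The expectation is therefore a step of modest size, more likely toward weaker than stronger inhibition, and possibly within the scatter. Compound 4 is estimated at 8000 nM in this assay, with a range from 2500 nM to 30000 nM, which means an expected step of a 1.6-fold higher number from compound 2 to compound 4 (0.20 log units; within the scatter).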

Compound 4, half-maximal inhibitory concentration: 20000 nM
Compound 4: middle estimate off by 2.5-fold (0.40 log units), on the low side, and the stated range covers the measured number.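

Among the compounds shown here, the exchange gives the first measured step on the shared core: in this assay, 2-fluorophenyl in place of 3-bromophenyl on a double-bonded chain carbon bound to an aromatic carbon brings a 4.0-fold higher number from compound 2 to compound 4 (0.60 log units; beyond the scatter) and so shows that this place responds to the aryl group it carries, even though both groups have the same heavy-atom count and the same counts of hydrogen-bond donors and acceptors. A number also survives this exchange, whereas, differing from compound 2 at the same place, compound 1 gives "not active" (no number reported) in the same test; steps to compound 1 and compound 3 cannot be read, since neither has a number. Nothing shown gives a measured reason for the size of this step.

Within the compounds shown, the halogen and its location in the group's name change together, so the shares of each in the step remain unsettled. Also open, from the compounds shown here alone, is how this place would respond to an aryl group carrying an amine or a carboxylic acid, and whether any such group would give a lower number than compound 2 does.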